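A few compounds are considered here, and "the series" means these few. Any claim that something is new, unique, unknown or untested is made for them only; others in the source may bear on it.

Three sulfonamides were tested in a functional assay on P388 cells (Mus musculus) for antiproliferative activity; a higher number here means a weaker inhibitor, a lower number a stronger inhibitor. Compound 1 `O=S(=O)(Nc1cccc2cc[nH]c12)c1ccc(Cl)cc1` gave 6 ug/mL, and compound 2 `N#Cc1ccc(S(=O)(=O)Nc2cccc3cc[nH]c23)cc1` gave 4.2 ug/mL. Between them stands one change, (chloro in place of cyano on an aromatic carbon), and it made a step of a 1.4-fold higher number from compound 2 to compound 1 (0.15 log units; within the scatter). Compound 3 `COc1ccc(S(=O)(=O)Nc2cccc3c(C#N)c[nH]c23)cc1` gave 0.17 ug/mL, the lowest number of the three; how its core differs from that of compound 2 is not broken down here. Compound 4 `COc1ccc(S(=O)(=O)Nc2cccc3c(Cl)c[nH]c23)cc1` is not yet measured. It differs from compound 3 by chloro in place of cyano on an aromatic carbon. This is the same kind of change as that from compound 2 to compound 1, but not the same: there the place was a six-membered aromatic ring of carbon only, para to a large group, here a five-membered aromatic ring with one nitrogen in a fused system. Because the earlier step was only a 1.4-fold higher number from compound 2 to compound 1 (0.15 log units; within the scatter), compound 4 is expected to stay near compound 3, with a step of about a 1.5-fold higher number from compound 3 to compound 4 (0.17 log units; within the scatter). Compound 4 is therefore estimated at 0.25 ug/mL, in a range from 0.08 ug/mL to 0.8 ug/mL.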

Compound 4, half-maximal inhibitory concentration: 0.76 ug/mL
Compound 4: middle estimate off by 3.0-fold (0.48 log units), on the low side; low and high end bracket the measured number.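

In this assay, chloro in place of cyano gave a 4.5-fold higher number from compound 3 to compound 4 (0.65 log units; beyond the scatter), whereas the same change on the core of compound 2 stayed within the scatter. The size of this change therefore did not carry over from one core to the other: the same change on two cores in this assay, a 1.4-fold higher number (0.15 log units; within the scatter) from compound 2 to compound 1 and a 4.5-fold higher number (0.65 log units; beyond the scatter) from compound 3 to compound 4, 3.1-fold (0.50 log units) apart, beyond the scatter of two such steps

The change also sits at a different place in each pair, so these two steps cannot separate the effect of the place from that of the rest of the core, and they set no rule for the series. The compounds shown leave open how an amine or a carboxylic acid would fare on the aromatic carbon two ring bonds from the ring nitrogen. Also open, as far as these compounds go, is whether the cyano-to-chloro step would keep its size on a third core.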